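Swapping fluoro for methoxy on compound 2

The compounds below may be only part of what the source reports. "The series", "measured", "known", "first", "only" and "open" are said of these compounds alone.

Three fluorinated compounds sharing one core have been tested in a functional assay on KB cells (Homo sapiens); a higher number here means that more compound is needed for the effect, a lower number that less compound is needed: compound 1 `COc1cc2nc(-c3ccccc3F)nc(O)c2cc1OC`, compound 2 `COc1cc2nc(-c3cccc(F)c3)nc(O)c2cc1OC` and compound 3 `COc1cc2nc(-c3ccc(F)cc3)nc(O)c2cc1OC`. Compound 1 gives < 5 ug/mL, which is a limit and not a number. Compound 2 gives > 20 ug/mL, which is also a limit. Compound 3 gives > 20 ug/mL, again a limit. Compound 2 therefore stands at the limit of > 20 ug/mL in this assay, at which 2 of the 3 values shown sit, without a number of its own.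

Compound 4 `COc1cccc(-c2nc(O)c3cc(OC)c(OC)cc3n2)c1` carries methoxy in place of fluoro on an aromatic carbon, meta to a large group: methoxy in place of fluoro on an aromatic carbon. Going by the values given here, no measured step makes this exchange, so the evidence is indirect. The data show an at least 4.0-fold higher number from compound 1 to compound 2 (0.60 log units; beyond the scatter) and also an at least 4.0-fold higher number from compound 1 to compound 3 (0.60 log units; beyond the scatter). Both steps lead away from 2-fluorophenyl, whereas compound 4, like compound 2, has its group meta to a large group. The data also show a step that the two limits leave unreadable from compound 2 to compound 3, so they cannot rank those two compounds.

On the strength of an at least 4.0-fold higher number from compound 1 to compound 2 (0.60 log units; beyond the scatter), compound 4 is expected to stay in the same range as compound 2 in this assay, with no step beyond the scatter in either direction. The expected step is a step that the limit leaves unreadable from compound 2 to compound 4. Compound 4 is estimated at 25 ug/mL, with an expected range of 10 ug/mL to 60 ug/mL.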

Compound 4, concentration for half-maximal effect: 19 ug/mL
Estimate against measurement, compound 4: 1.3-fold (0.12 log units) above, within the range that was stated.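

With methoxy in place of fluoro on an aromatic carbon, meta to a large group, the series gains its first actual number in this assay: compound 4 gives 19 ug/mL. The three fluorinated compounds stand only at limits. The exchange comes out as an at least 1.0-fold lower number from compound 2 to compound 4 (0.02 log units; that floor lies within the scatter), so only a floor can be read, and the true gap may be negligible or larger, since compound 2 has no number of its own. The value of compound 2 remains a limit and not a number, and it is shared with one other compound: the limit of > 20 ug/mL in this assay, at which 2 of the 4 values shown sit.

Going by these compounds alone, the step between compound 2 and compound 3 still cannot be read, so the two limits give no ranking of those compounds, and the size of the exchange from fluoro to methoxy stays unresolved. The compounds shown also leave open how an amine, a carboxylic acid or a longer chain such as butoxy would behave at this position, and whether methoxy would read the same where compound 1 and compound 3 carry their fluoro.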